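Replacing a benzyl group on the ring nitrogen of a weak antiproliferative scaffold

A few compounds are considered here, and "the series" means these few. Any claim that something is new, unique, unknown or untested is made for them only; others in the source may bear on it.

Compound 1, `NC(=O)c1c(NC(=O)c2ccccc2Cl)sc2c1CCN(Cc1ccc(Cl)cc1)C2`: > 50000 nM, a limit of the assay.
Compound 2, `NC(=O)c1c(NC(=O)c2ccc(C(F)(F)F)cc2)sc2c1CCN(Cc1ccc(Cl)cc1)C2`: > 50000 nM, a limit of the assay.
Compound 3, `Cc1ccc(C(=O)Nc2sc3c(c2C(N)=O)CCN(Cc2c(Cl)cccc2Cl)C3)cc1`: 47400 nM.

In a functional assay on HeLa cells (Homo sapiens) for antiproliferative activity, with a stated time of 24 h (a higher number here means a weaker inhibitor, a lower number a stronger inhibitor), compound 1 gives > 50000 nM, which is a limit of the assay rather than a number. Compound 2 likewise reaches only a limit in this assay. Compound 3 gives 47400 nM in this assay, close to where the other two sit. Going by the values given here, the one measured step, a step that the two limits leave unreadable from compound 1 to compound 2, cannot be read because both ends are limits, so no measured step bears on the change to compound 4.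

Compound 4, `NC(=O)c1c(NC(=O)c2ccccc2Cl)sc2c1CCN(C(=S)Nc1ccccc1I)C2`, differs from compound 1 in that (a group of 10 heavy atoms (7 carbon, 1 nitrogen, 1 sulfur, 1 iodine; one six-membered aromatic ring of carbon only) in place of a group of 8 heavy atoms (7 carbon, 1 chlorine; one six-membered aromatic ring of carbon only), on an amine nitrogen in a ring). With nothing measured to guide the size of this step, and because of the limit of > 50000 nM in this assay, at which 2 of the 3 values shown sit, compound 4 is expected to remain a weak inhibitor, with the step of a number no higher from compound 1 to compound 4 (the limit leaves the size open) estimated as small or none beyond the scatter. Compound 4 is therefore estimated at 50000 nM in this assay, within a range from 15000 nM to 150000 nM.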

Compound 4, half-maximal inhibitory concentration: 29000 nM
Compound 4: the middle estimate sits 1.7-fold (0.24 log units) above what was measured, within the range that was stated.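

In this assay, placing the group that carries sulfur and iodine on an amine nitrogen in a ring, where 4-chlorobenzyl stood, gives an at least 1.7-fold lower number from compound 1 to compound 4 (0.23 log units; that floor lies within the scatter). Compound 1 gives > 50000 nM, which is a limit of the assay. The position therefore accepts this quite different group, which brings a hydrogen-bond donor and a double bond outside aromatic rings, and still gives a readable number, but no gain beyond the scatter can be shown and the compounds remain weak: the limit of > 50000 nM in this assay, at which 2 of the 4 values shown sit.

Which part of the entering group matters, whether the sulfur, the iodine or the nitrogen that carries the phenyl ring, remains open. So does the outcome with a urea, with oxygen in place of sulfur, or with a plain phenyl ring in place of the iodophenyl ring.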